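A few compounds are considered here, and "the series" means these few. Any claim that something is new, unique, unknown or untested is made for them only; others in the source may bear on it.

Measured in a functional assay on CCRF-CEM cells (Homo sapiens) for antiproliferative activity, with a stated time of 72 h; on this read-out higher numbers stand for weaker inhibition and lower numbers for stronger inhibition:
- compound 1 `OC[C@H]1O[C@@H](n2cnc3c(NCc4ccccc4F)ncnc32)[C@H](O)[C@@H]1O`: 4600 nM
- compound 2 `OC[C@H]1O[C@@H](n2cnc3c(NCc4ccc(F)cc4F)ncnc32)[C@H](O)[C@@H]1O`: 7100 nM
- compound 3 `OC[C@H]1O[C@@H](n2cnc3c(NCc4cc(O)cc(O)c4)ncnc32)[C@H](O)[C@@H]1O`: "not determined" (no result reported)

Going by the values given here, only two compounds have numbers, and the gap between them is a 1.5-fold higher number from compound 1 to compound 2 (0.19 log units; within the scatter). Compound 1 therefore holds no clear rank, and compound 3 offers no number for comparison.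

Compound 4 `OC[C@H]1O[C@@H](n2cnc3c(NCc4ccccc4OC(F)(F)F)ncnc32)[C@H](O)[C@@H]1O` comes from compound 1 through a single change, trifluoromethoxy in place of fluoro on an aromatic carbon, ortho to a large group: trifluoromethoxy in place of fluoro on an aromatic carbon.

Among the compounds with values here, the one measured step is a different swap, fluoro in place of hydrogen on an aromatic carbon, so it bears on this change only loosely. The data contain no measured replacement of fluoro by a larger group. With that single step inside the scatter, no step beyond the scatter is expected in this assay, and neither direction is favoured. The estimated step is a 1.1-fold higher number from compound 1 to compound 4 (0.04 log units; within the scatter). For compound 4 the estimate is 5000 nM, with an expected range from 1700 nM to 15000 nM.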

Compound 4, half-maximal inhibitory concentration: > 166000 nM
Compound 4: a limit, no number (the forecaster's own chance of this, stated with the estimate: 15%); middle value at least 33-fold (1.52 log units) away from the limit.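

In this assay, going by these compounds alone, the swap of fluoro for trifluoromethoxy gives an at least 36-fold higher number from compound 1 to compound 4 (1.55 log units; beyond the scatter) and so shows that this place on the aromatic ring does not tolerate every group, something the only other step, a 1.5-fold higher number from compound 1 to compound 2 (0.19 log units; within the scatter), could not reveal. Activity at this place therefore depends strongly on which group sits there, although this single change cannot say which feature of the entering group matters. The figure for compound 4 is a limit of the assay, not a number: the limit of > 166000 nM in this assay, at which 1 of the 4 values shown sits.

As far as these compounds go, whether the oxygen atom or the three fluorine atoms of trifluoromethoxy drive this weakening stays open. A methoxy or a trifluoromethyl group at the same place would help separate the two, and the effect of a chlorine atom or an amine there is also unknown from the compounds shown.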